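The compounds below may be only part of what the source reports. "The series", "measured", "known", "first", "only" and "open" are said of these compounds alone.

Measured so far in an ADME assay on NIH3T3 cells (Mus musculus) for cytotoxicity, read by MTT assay, with a stated time of 24 h; a lower number here means a stronger inhibitor, a higher number a weaker inhibitor:
- Compound 1 `COc1ccc(/C=N/n2c(S)nnc2-c2cnccn2)cc1OC`: 163000 nM
- Compound 2 `COc1cc(/C=N/n2c(S)nnc2-c2cnccn2)cc(OC)c1OC`: 169000 nM

Compound 1 has a single neighbour on this scale, compound 2, and the two values lie within the usual scatter of each other. Neither can be ranked ahead of the other.

The next compound to be tested is compound 3 `COc1cc(OC)c(OC)cc1/C=N/n1c(S)nnc1-c1cnccn1`. It differs from compound 1 in one place: methoxy in place of hydrogen on an aromatic carbon. The new methoxy stands on an aromatic carbon of a six-membered aromatic ring of carbon only, ortho to a large group, meta to a methoxy group and para to a methoxy group.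

Going by the values given here, only one measured step is of the same kind, methoxy in place of hydrogen on an aromatic carbon: a 1.0-fold higher number from compound 1 to compound 2 (0.02 log units; within the scatter). Among the compounds with values here, it is a single example, and no measured compound carries a methoxy ortho to a large group. With that caution, no change beyond the scatter is expected in this assay. The expected step is a 1.0-fold higher number from compound 1 to compound 3 (0.01 log units; within the scatter). For compound 3 the estimate is 165000 nM, with an expected range from 90000 nM to 300000 nM.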

Compound 3, half-maximal inhibitory concentration: 143000 nM
Estimate against measurement, compound 3: 1.2-fold (0.06 log units) above; the measured number falls inside the stated range.
By their numbers in this assay, from the lowest: compounds 3, 1 and 2 (each within the scatter of the next).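

Going by these compounds alone, the new methoxy stands ortho to a large group, a place on the six-membered aromatic ring of carbon only that no earlier compound tested, and in this assay this change gives a 1.1-fold lower number from compound 1 to compound 3 (0.06 log units; within the scatter). Within the data shown here, the only earlier step of this kind, a 1.0-fold higher number from compound 1 to compound 2 (0.02 log units; within the scatter), also stays within the scatter, so adding a methoxy to this ring has now twice left the number in this assay without a change that can be told from ordinary repeat variation, with the new group at two different places. Among these compounds, these are only two examples on a single core, and no measurement is available to explain why the readings stay so close.

What the compounds shown leave open is whether this position responds to anything other than a methoxy, since a hydroxy group, a chlorine atom, an amine or a longer chain such as butoxy could behave differently here. They also leave open whether changing the shared core away from this ring would shift the number in this assay beyond the scatter.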